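The source may hold more compounds than are shown below. What is called first, only, known or untested is meant among the compounds shown, and "the series" means these compounds.

Measured compounds:
Compound 1 `O=C(CCc1ccc(C(F)(F)F)cc1)Nc1ccc2nc(N3CCC(c4ccccc4)C3)ccc2c1` gives 25 nM in an assay on isolated protein for displacement of a labelled ligand from melanin-concentrating hormone receptor 1 (Homo sapiens); a lower number here means a stronger inhibitor, a higher number a weaker inhibitor.
Compound 2 `CC(=O)NC1CCN(c2ccc3cc(NC(=O)CCc4ccc(C(F)(F)F)cc4)ccc3n2)C1` gives 5 nM.
Compound 3 `O=C(CCc1ccc(C(F)(F)F)cc1)Nc1ccc2nc(N3CC4CC3CO4)ccc2c1` gives 13 nM.

Among these three, compound 3 stands second highest: its number lies within the scatter of compound 1, as seen in a 1.9-fold lower number from compound 1 to compound 3 (0.28 log units; within the scatter), while the gap to compound 2, a 2.6-fold higher number from compound 2 to compound 3 (0.41 log units; beyond the scatter), is beyond the scatter. Compound 4 `NC1CCN(c2ccc3cc(NC(=O)CCc4ccc(C(F)(F)F)cc4)ccc3n2)C1` has not yet been measured. It differs from compound 3 in one place: a group of 6 heavy atoms (4 carbon, 2 nitrogen; one five-membered non-aromatic ring with 1 hetero atom) in place of a group of 7 heavy atoms (5 carbon, 1 nitrogen, 1 oxygen; 2 five-membered non-aromatic rings with 1 hetero atom each), on an aromatic carbon. Within the data shown here, two measured steps bear on this change. The step of a 2.6-fold higher number from compound 2 to compound 3 (0.41 log units; beyond the scatter) shows that replacing the acetamido-bearing ring with the group of 7 heavy atoms costs a modest amount, and a 5.0-fold lower number from compound 1 to compound 2 (0.70 log units; beyond the scatter) shows that a nitrogen-bearing substituent on the saturated ring carbon is favoured over phenyl. Compound 4 carries the 3-aminopyrrolidin-1-yl group, close in kind to the substituent of compound 2, so a modest move to a lower number is expected in a 1.6-fold lower number from compound 3 to compound 4 (0.21 log units; within the scatter). Compound 4 is therefore estimated at 8 nM, within a range of 3 nM to 25 nM.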

Compound 4, half-maximal inhibitory concentration: 12 nM
Compound 4: middle estimate off by 1.5-fold (0.18 log units), on the low side; measured number inside the range.
By their numbers in this assay, from the lowest: compound 2; then compounds 4, 3 and 1 (each within the scatter of the next, the first and the last beyond it).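

In this assay, the position next to the ring nitrogen tolerates the exchange of the bridged group for 3-aminopyrrolidin-1-yl, with a 1.1-fold lower number from compound 3 to compound 4 (0.03 log units; within the scatter) showing no change beyond the scatter. The new pairs separate the parts of the substituent on the saturated ring carbon: the amino group alone still improves on phenyl, with a 2.1-fold lower number from compound 1 to compound 4 (0.32 log units; beyond the scatter), while hydrogen in place of acetyl on the amine nitrogen gives up potency, with a 2.4-fold higher number from compound 2 to compound 4 (0.38 log units; beyond the scatter), so the acetyl counts for something in its own right. No measurement shown here offers an explanation for these differences.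

On these data alone, it remains open whether a longer acyl chain such as propanoyl, or a methanesulfonyl group, on that amine nitrogen would match the acetyl. A dimethylamino group on the same ring carbon is equally untested among the compounds shown.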